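Adding a chlorine to a DNA-binding amidine

This account rests on a few compounds, and the source may have more. Where it says the series, first, only, none or still open, it means among the compounds named here.

Of the compounds shown here, two sharing one core have been measured. Among the compounds with values here, compound 1 `CC(C)CCc1sc(NC(=O)c2cc(NC(=O)c3cc(NC(=N)c4cnc5ccccc5c4)cn3C)cn2C)nc1C(=O)NCCCN(C)C` carries a quinolin-3-yl group on a carbon with a double bond to nitrogen; in an assay on nucleic acid for binding affinity to Salmon testes DNA (Salmonidae), tested at 10 uM (a higher number here means that the compound stabilises the target more against heat, a lower number that the compound stabilises the target less), compound 1 gives 2 degrees C. Compound 2 `CC(C)CCc1sc(NC(=O)c2cc(NC(=O)c3cc(NC(=N)c4ccccc4)cn3C)cn2C)nc1C(=O)NCCCN(C)C` carries a phenyl there instead, and in this assay compound 2 gives 7 degrees C. The single measured step, a number 5.0 degrees C higher from compound 1 to compound 2 (beyond the scatter), is large. Compound 2 thus stands highest of the two numbers, with compound 1 the nearest and well below it.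

Compound 3 `CC(C)CCc1sc(NC(=O)c2cc(NC(=O)c3cc(NC(=N)c4ccc(Cl)cc4)cn3C)cn2C)nc1C(=O)NCCCN(C)C` has not yet been measured. It differs from compound 2 only by chloro in place of hydrogen on an aromatic carbon. No measured step involves a chloro group; the only step seen concerns swapping the whole ring, so nothing shown bears directly on this smaller change. The expectation is therefore a step of about no change at the digits printed from compound 2 to compound 3 (within the scatter), that is, no change beyond the scatter. For compound 3 the estimated result in this assay is 7 degrees C, expected to fall between 4 degrees C and 10 degrees C.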

Compound 3, shift of the target's melting temperature: 4 degrees C
Compound 3: the middle estimate sits 3.0 degrees C above what was measured, and the stated range covers the measured number.
By their numbers in this assay, from the lowest: compound 1; then compound 3; then compound 2.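

Within the data shown here, the earlier pair showed only that swapping a whole ring on the carbon with a double bond to nitrogen matters; this result shows that the same part of the molecule also responds to a much smaller change. In this assay, adding one chlorine atom to the phenyl ring, para to a large group, gives a number 3.0 degrees C lower from compound 2 to compound 3 (beyond the scatter), so even a single heavy atom at this position changes the read-out beyond the scatter. The 4-chlorophenyl group still ranks above quinolin-3-yl, with a number 2.0 degrees C higher from compound 1 to compound 3 (beyond the scatter), so the chlorine gives back only part of the gain seen in a number 5.0 degrees C higher from compound 1 to compound 2 (beyond the scatter), and nothing available explains why the added chlorine lowers the number.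

One chlorine at one position cannot show whether the drop is specific to chlorine or would follow any group placed there, such as a fluorine, a methyl, a methoxy or an amine. The compounds shown also leave open whether a chlorine elsewhere on the phenyl ring would give a similar number, and whether any group at all could raise the number above that of compound 2.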